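The source may report more compounds than this note shows. Statements on the series, on what has been measured and on what is new or still open speak of the compounds shown alone.

Measured compounds:
compound 1 `COC(c1cc(Cl)c2c(c1Cl)C(=O)N(Cc1c(C)cc(C)[nH]c1=O)CC2)C1CCN(C(C)=O)CC1` — 2000 nM; 11 nM (2 entries)
compound 2 `Cc1cc(C)c(CN2CCc3c(Cl)cc([C@@H](C)CO)c(Cl)c3C2=O)c(=O)[nH]1` — 1040 nM
compound 3 `COc1cc(C)[nH]c(=O)c1CN1CCc2c(Cl)cc([C@@H](O)C3COC3)c(Cl)c2C1=O` — > 32000 nM

In an assay on cells for inhibition of histone-lysine N-methyltransferase EZH2 (Homo sapiens), read by ELISA, with a stated time of 72 h (a lower number here means a stronger inhibitor, a higher number a weaker inhibitor), compound 1 gives 2000 nM; 11 nM (2 entries); the spread between the two entries is recorded as the several entries of compound 1 in this assay, 2000 nM; 11 nM (2 entries), so the figure for compound 1 cannot be read as a single number. For compound 3 the result in this assay is a limit, > 32000 nM, and no finite value is known. Among the measured compounds shown here, compound 2, then, holds the only single number in this assay, with 1040 nM. For the measured compounds named here, the other two results, that of compound 3 and that of compound 1, are not single numbers, and no step between measured compounds can be drawn from them.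

Compound 4 `Cc1cc(C)c(CN2CCc3c(Cl)cc([C@H](C)CO)c(Cl)c3C2=O)c(=O)[nH]1` differs from compound 2 in one place: the two compounds have the same atoms and bonds and differ only in configuration as drawn: 1 of 1 stereo elements differ; a stereocentre at a saturated chain carbon is drawn R in compound 2 and S in compound 4.

Going by the values given here, no measured pair separates the two configurations here, so the direction of the step is uncertain. A change of configuration at a single stereocentre can leave the number where it is or move it well beyond the scatter in either direction. Taking compound 2 as the only anchor, the estimate for compound 4 in this assay is 700 nM, spanning 80 nM to 6000 nM, which corresponds to an expected step of a 1.5-fold lower number from compound 2 to compound 4 (0.17 log units; within the scatter).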

Compound 4, half-maximal inhibitory concentration: 129 nM
For compound 4 the middle estimate is 5.4-fold (0.73 log units) above the measured one; the range from low to high includes it.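

In this assay, the configuration at the saturated chain carbon proves to matter, with an 8.1-fold lower number from compound 2 to compound 4 (0.91 log units; beyond the scatter), so that S as drawn goes with the lower number and R with the higher one in this pair. Among the compounds shown here, this is the first step in the set that can be read, and it can be tied to this one stereocentre because nothing else changes between the two structures: the fact that compounds 2 and 4 differ only in the configuration as drawn. The earlier compounds shown here could not show this, and compound 1 in particular offers no single figure to set beside the new one: the several entries of compound 1 in this assay, 2000 nM; 11 nM (2 entries).

For compound 3 the result in this assay remains a limit, > 32000 nM. As far as these compounds go, what stays open is whether S would again go with the lower number if the hydroxyl of this chain gave way to an amine or a carboxylic acid, or if the chain were longer, since a single pair of configurations speaks only for the chain carried by compound 2 and compound 4.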